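A few compounds are considered here, and "the series" means these few. Any claim that something is new, unique, unknown or untested is made for them only; others in the source may bear on it.

Series notes. Three analogs on the shared core have been run in a functional assay on ileum (Cavia porcellus) for antagonist activity at cysteinyl leukotriene receptor (Homo sapiens) (on this read-out lower numbers stand for stronger inhibition and higher numbers for weaker inhibition), so far: compound 1 `CCC(CC)(CC(=O)Nc1cccc(OCc2ccc3ccc(Cl)cc3n2)c1)C(=O)O` gives 0.8 nM; compound 2 `CCC(CC)(CC(=O)Nc1cccc(OCc2ccc3ccc(Br)cc3n2)c1)C(=O)O` gives 4 nM; compound 3 `CCC(CC)(CC(=O)Nc1cccc(OCc2ccc3ccc(C(F)(F)F)cc3n2)c1)C(=O)O` gives 3 nM. Compound 3 holds the second highest of the three numbers, sitting within the scatter of compound 2 and well apart from compound 1, the latter gap being a 3.8-fold higher number from compound 1 to compound 3 (0.57 log units; beyond the scatter).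

Compound 4 `CCC(CC)(CC(=O)Nc1cccc(OCc2ccc3ccc(C)cc3n2)c1)C(=O)O` is the next member, differing from compound 3 by methyl in place of trifluoromethyl on an aromatic carbon. Going by the values given here, no measured pair covers a methyl, so the step has no direct precedent. The two changes at the same position that were measured are a 5.0-fold higher number from compound 1 to compound 2 (0.70 log units; beyond the scatter) and a 3.8-fold higher number from compound 1 to compound 3 (0.57 log units; beyond the scatter), with a 1.3-fold lower number from compound 2 to compound 3 (0.12 log units; within the scatter) showing the two heavier substituents close together. Swaps at this position have so far moved this assay by modest amounts only, and no value has fallen outside a narrow band.

On that basis a change of the order of a 1.5-fold lower number from compound 3 to compound 4 (0.18 log units; within the scatter) is expected, which puts the estimate for compound 4 at 2 nM, likely between 0.5 nM and 8 nM.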

Compound 4, half-maximal inhibitory concentration: 11 nM
Compound 4: middle estimate off by 5.5-fold (0.74 log units), on the low side; measured number outside the range, above it.
By their numbers in this assay, from the lowest: compound 1; then compounds 3 and 2 (each within the scatter of the next); then compound 4.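

In this assay the methyl group of compound 4 does not fall in with the heavier substituents at this aromatic carbon: it gives a higher number than trifluoromethyl (a 3.7-fold higher number from compound 3 to compound 4 (0.56 log units; beyond the scatter)) and than bromo (a 2.8-fold higher number from compound 2 to compound 4 (0.44 log units; beyond the scatter)). Against chloro the change gives the first large step at this position (a 14-fold higher number from compound 1 to compound 4 (1.14 log units; beyond the scatter)), so the position discriminates more widely than the earlier modest steps showed, and compound 4 is the weakest of the four. Nothing available accounts for this placing of methyl.

From the compounds shown here alone, with only four groups compared here, it remains open whether fluoro, a nitrile or a methoxy group would sit nearer chloro or nearer methyl. Going by these compounds, it is also open whether this order holds when the shared core is changed elsewhere.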